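A few compounds are considered here, and "the series" means these few. Any claim that something is new, unique, unknown or untested is made for them only; others in the source may bear on it.

Three compounds sharing one core have been tested so far:

Compound 1, `CC(C)S(=O)(=O)OC1CCC(CN2CCN(c3cc(=O)c4cc(C(F)(F)F)cc([N+](=O)[O-])c4s3)CC2)CC1`: > 64 ug/mL
Compound 2, `O=C(OC1CCC(CN2CCN(c3cc(=O)c4cc(C(F)(F)F)cc([N+](=O)[O-])c4s3)CC2)CC1)c1cccs1`: > 64 ug/mL
Compound 3, `O=c1cc(N2CCN(CC3CCC(OS(=O)(=O)c4ccccc4)CC3)CC2)sc2c([N+](=O)[O-])cc(C(F)(F)F)cc12`: > 64 ug/mL

These values come from an ADME assay on Vero cells (Chlorocebus sabaeus) for cytotoxicity, read by MTT assay, with a stated time of 48 h; on this read-out lower numbers stand for stronger inhibition and higher numbers for weaker inhibition. In this assay compound 2 gives > 64 ug/mL, which is a limit of the assay and not a measured number. Compound 1 and compound 3 both sit at the limit of > 64 ug/mL in this assay, at which 3 of the 3 values shown sit, as well. Compound 4, `CC(C)C(=O)OC1CCC(CN2CCN(c3cc(=O)c4cc(C(F)(F)F)cc([N+](=O)[O-])c4s3)CC2)CC1`, has not yet been tested. It differs from compound 2 in a single place: isopropyl in place of thiophen-2-yl on a carbonyl carbon. Among the measured compounds shown here, the steps measured so far are the only guide to what such a change might do, but each of them runs between two limits: a step that the two limits leave unreadable from compound 1 to compound 2, a step that the two limits leave unreadable from compound 2 to compound 3 and a step that the two limits leave unreadable from compound 1 to compound 3. None of them shows whether exchanging the group on the carbonyl carbon, or the whole group on the oxygen on a saturated carbon, moves the read-out at all. With every result at the limit of > 64 ug/mL in this assay, at which 3 of the 3 values shown sit, the most that can reasonably be expected is that compound 4 also reaches that limit, so the step that the limit leaves unreadable from compound 2 to compound 4 is expected to be small or none. Compound 4 is therefore estimated at 80 ug/mL, with a range from 40 ug/mL to 160 ug/mL.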

Compound 4, half-maximal inhibitory concentration: > 64 ug/mL
Compound 4: a limit, no number; the forecaster's own chance of this, stated with the estimate: 85%; the middle value does not contradict the limit.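

Compound 4 gives > 64 ug/mL, which is a limit of the assay and not a measured number. No step between compound 1, compound 2, compound 3 and compound 4 can be read, because all four results stop at the same point: the limit of > 64 ug/mL in this assay, at which 4 of the 4 values shown sit.

The compounds shown leave open whether changing the group on the oxygen on a saturated carbon moves the read-out at all.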